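A few compounds are considered here, and "the series" means these few. Any claim that something is new, unique, unknown or untested is made for them only; others in the source may bear on it.

Measured in a functional assay on VCaP cells (Homo sapiens) for antiproliferative activity, read by CCK-8 assay, with a stated time of 6 days (on this read-out higher numbers stand for weaker inhibition and lower numbers for stronger inhibition), on the shared core:
compound 1 `CCN(c1ccc(C#N)c(Cl)c1)c1cc(-c2ccncc2)ccc1C` gives 2900 nM
compound 2 `CCN(c1ccc(C#N)c(Cl)c1)c1cc(-c2ccnn2C)ccc1C` gives 1670 nM
compound 3 `CCN(c1ccc(C#N)c(Cl)c1)c1cc(-c2cccs2)ccc1C` gives "not determined" (no result reported)

Compound 3 therefore offers no number from which a step can start. The change to compound 4 `CCN(c1ccc(C#N)c(Cl)c1)c1cc(-c2c[nH]nc2C)ccc1C` is 3-methyl-1H-pyrazol-4-yl in place of thiophen-2-yl on an aromatic carbon and sits on an aromatic carbon of a six-membered aromatic ring of carbon only, para to a methyl group. Among the measured compounds shown here, the only measured step is a 1.7-fold lower number from compound 1 to compound 2 (0.24 log units; within the scatter) and it stays within the scatter, with 1-methyl-1H-pyrazol-5-yl in place of pyridin-4-yl. That step involves neither thiophen-2-yl nor 3-methyl-1H-pyrazol-4-yl, so it bears on this change only indirectly. The anchors are compound 1 at 2900 nM and compound 2 at 1670 nM in the same read-out. Measured against these two compounds, no step beyond the scatter is expected in this assay and no direction can be assigned. With so few anchors the range stays wide. Compound 4 is estimated at 1700 nM with an expected range of 500 nM to 5500 nM in this read-out.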

Compound 4, half-maximal inhibitory concentration: 3190 nM
Beside the measured number, compound 4's estimate is 1.9-fold (0.27 log units) below it, and the stated range covers the measured number.
By their numbers in this assay, from the lowest: compounds 2, 1 and 4 (each within the scatter of the next).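

In this assay, the new ring gives a 1.9-fold higher number from compound 2 to compound 4 (0.28 log units; within the scatter) and a 1.1-fold higher number from compound 1 to compound 4 (0.04 log units; within the scatter), so neither step separates 3-methyl-1H-pyrazol-4-yl from the earlier rings. On this aromatic carbon, para to a methyl group, pyridin-4-yl, 1-methyl-1H-pyrazol-5-yl and 3-methyl-1H-pyrazol-4-yl therefore all lie within the scatter of one another, including the one ring here with a hydrogen-bond donor counted on it. No measured evidence accounts for these numbers.

The step from compound 3 to compound 4 cannot be read, so the exchange of thiophen-2-yl for 3-methyl-1H-pyrazol-4-yl stays without a size or direction. On these data alone, it also remains open whether a non-ring group at this carbon, such as a carboxylic acid, an amine or a longer alkyl chain, would give a step beyond the scatter.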